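This account rests on a few compounds, and the source may have more. Where it says the series, first, only, none or still open, it means among the compounds named here.

Measured so far:
compound 1 `c1ccc(Oc2ccc3c(NCCCNCc4ccco4)ccnc3c2)cc1` — 15200 nM
compound 2 `COc1ccc(-c2ccc3c(NCCCNCc4ccco4)ccnc3c2)cc1` — 6000 nM
compound 3 `c1coc(CNCCCNc2ccnc3cc(-c4cccc5ccccc45)ccc23)c1` — 5600 nM

All three numbers come from an ADME assay on HepG2 cells (Homo sapiens) for cytotoxicity, read by luminescence, CellTiter-Glo and ATP content, with a stated time of 72 h; a higher number here means that more compound is needed for the effect, a lower number that less compound is needed. Compound 1 stands highest of the three: the step of a 2.5-fold lower number from compound 1 to compound 2 (0.40 log units; beyond the scatter) and the step of a 2.7-fold lower number from compound 1 to compound 3 (0.43 log units; beyond the scatter) both lie beyond the scatter, while a 1.1-fold lower number from compound 2 to compound 3 (0.03 log units; within the scatter) stays within it. Both measured steps away from compound 1 alter the group on the aromatic carbon of the shared core; the (furan-2-yl)methyl end of the chain is the same in all three compounds.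

Compound 4 `COc1ccc(F)cc1CNCCCNc1ccnc2cc(Oc3ccccc3)ccc12` keeps the phenoxy group of compound 1 and differs at the other end of the chain: 5-fluoro-2-methoxyphenyl in place of furan-2-yl on a saturated chain carbon bound to an amine nitrogen. Among the compounds with values here, no measured step touches this position. Within the data shown here, nothing among the three compounds shows how this assay answers a change at the saturated chain carbon bound to the amine nitrogen; the only general guide is that the two measured steps from compound 1, each at a different place, were modest. Among the measured compounds shown here, with no bearing step, the expectation is no step beyond the scatter, and compound 4 is expected to sit close to compound 1, a 1.3-fold lower number from compound 1 to compound 4 (0.10 log units; within the scatter). Compound 4 is estimated at 12000 nM, with a range from 5000 nM to 30000 nM.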

Compound 4, half-maximal effective concentration: 1500 nM
For compound 4 the middle estimate is 8.0-fold (0.90 log units) above the measured one; the measured number lies below the stated range.
By their numbers in this assay, from the lowest: compound 4; then compounds 3 and 2 (each within the scatter of the next); then compound 1.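

The saturated chain carbon bound to the amine nitrogen is a responsive position in this assay: a 10-fold lower number from compound 1 to compound 4 (1.01 log units; beyond the scatter), a larger change than either step at the aromatic carbon of the shared core, a 2.5-fold lower number from compound 1 to compound 2 (0.40 log units; beyond the scatter) and a 2.7-fold lower number from compound 1 to compound 3 (0.43 log units; beyond the scatter). Replacing furan-2-yl, a five-membered aromatic ring with one hetero atom, with 5-fluoro-2-methoxyphenyl, a six-membered aromatic ring of carbon only, adds heavy atoms but leaves the counts of hydrogen-bond donors and acceptors unchanged, and neither group carries a net charge, so those counts do not track this step. No measurement at hand gives a cause for the step.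

Within the data shown here, the single change alters the ring, the fluorine and the methoxy group together, so a plain benzyl, a 2-methoxybenzyl or a 3-fluorobenzyl in place of the (furan-2-yl)methyl end would be needed to show which part carries the step. On these data alone, it also remains open whether 5-fluoro-2-methoxybenzyl gives a step of similar size when paired with the 4-methoxyphenyl group of compound 2 or the naphthalen-1-yl group of compound 3.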